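The source may hold more compounds than are shown below. What is called first, only, known or untested is meant among the compounds shown, and "the series" means these compounds.

Working notes on the series. The shared core of compound 1 `COC(=O)CNc1cc(CS(=O)(=O)/C=C/c2c(OC)cc(OC)cc2OC)ccc1OC` carries a ((methoxycarbonyl)methyl)amino group on the aromatic ring. In a functional assay on DU-145 cells (Homo sapiens) for cytotoxicity, read by trypan blue exclusion, with a stated time of 96 h (on this read-out higher numbers stand for weaker inhibition and lower numbers for stronger inhibition), compound 1 gives 100 nM, the lowest of the two numbers recorded so far. For the measured compounds named here, compound 2 `COC(=O)CNc1cc(CS(=O)(=O)/C=C/c2cc(OC)c(OC)c(OC)c2)ccc1OC` is the only other measured member; in this assay compound 2 gives 75000 nM, a number far beyond the scatter from that of compound 1, so the two values show how widely the series can range in this read-out, although no single-point step connects them.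

Compound 3 `COc1cc(OC)c(/C=C/S(=O)(=O)Cc2ccc(OC)c(NC(C(=O)O)c3ccccc3)c2)c(OC)c1` has not yet been measured. It differs from compound 1 as follows: carboxy(phenyl)methyl in place of (methoxycarbonyl)methyl on a nitrogen on an aromatic ring. The new group keeps one hydrogen-bond donor and one acceptor where the old one had two acceptors, and it brings in a six-membered aromatic ring of carbon only.

Going by the values given here, no measured step covers a change of this kind, so the expectation rests on compound 1 alone. The step from compound 1 to compound 3 is expected to be a modest loss, a 3.0-fold higher number from compound 1 to compound 3 (0.48 log units; beyond the scatter), somewhat beyond the scatter. Compound 3 is therefore estimated at 300 nM in this assay, with a range of 50 nM to 3000 nM.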

Compound 3, half-maximal inhibitory concentration: 20 nM
For compound 3 the middle estimate is 15-fold (1.18 log units) above the measured one; the whole stated range lies above it.
By their numbers in this assay, from the lowest: compound 3; then compound 1; then compound 2.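

In this assay, the nitrogen on the aromatic ring accepts a substantial change without loss: carboxy(phenyl)methyl in place of (methoxycarbonyl)methyl gives a 5.0-fold lower number from compound 1 to compound 3 (0.70 log units; beyond the scatter), beyond the scatter. For the compounds shown here, this is the first single-place step, and it shows that this position affects the read-out and that the larger group, with its six-membered aromatic ring of carbon only and its hydrogen-bond donor, is compatible with a lower number than compound 1 gives. No supporting data bear on why the number falls, so the step stands as an observation only.

The step changes two things at once, so the share of the free carboxylic acid and that of the phenyl ring cannot be told apart: a carboxymethyl group on the same nitrogen, or a (methoxycarbonyl)(phenyl)methyl group, would separate them. Also open, from the compounds shown here alone, is whether the same change carries over to the core of compound 2, and whether an amide or a longer chain in this place would follow the same direction.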